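Carboxylate linker length on a thiazole anilide series

A few compounds are considered here, and "the series" means these few. Any claim that something is new, unique, unknown or untested is made for them only; others in the source may bear on it.

Compounds measured so far:
compound 1, `Cc1nc(-c2ccc(C(F)(F)F)cc2)sc1CNc1ccc(C(=O)O)cc1`, < 10000 nM
compound 2, `Cc1nc(-c2ccc(C(F)(F)F)cc2)sc1CNc1ccc(CCCC(=O)O)cc1`, < 10000 nM

In a functional assay on CHO cells for agonist activity at Free fatty acid receptor 1 (Homo sapiens) (on this read-out lower numbers stand for an effect already at smaller amounts and higher numbers for an effect only at larger amounts of compound), compound 1 gives only a limit, < 10000 nM. In this assay compound 2 likewise gives only a limit, < 10000 nM. Compound 2 therefore stands at the limit of < 10000 nM in this assay, at which 2 of the 2 values shown sit, without a number of its own. Among the measured compounds shown here, the only measured step, a step that the two limits leave unreadable from compound 1 to compound 2, is unreadable in size. Compound 3, `Cc1nc(-c2ccc(C(F)(F)F)cc2)sc1CNc1ccc(/C=C/C(=O)O)cc1`, differs from compound 2 by 2-carboxyethenyl in place of 3-carboxypropyl on an aromatic carbon. For the measured compounds named here, no measured step bears readably on this change, so no direction beyond the scatter is expected; compound 3 is expected to give 1500 nM, in the range 150 nM to 10000 nM, a step that the limit leaves unreadable from compound 2 to compound 3.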

Compound 3, half-maximal effective concentration: 36.3 nM
Compound 3: middle estimate off by 41-fold (1.62 log units), on the high side; the measured number lies below the stated range.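

The steps from compound 1 and from compound 2 to compound 3 cannot be read, as both compounds give only a limit: the limit of < 10000 nM in this assay, at which 2 of the 3 values shown sit.

Left open is how far 2-carboxyethenyl differs in size of effect from carboxy or 3-carboxypropyl on the shared core.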